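A Small Fluoro in Place of a Large Benzyl Ether

The source may hold more compounds than are shown below. What is called first, only, known or untested is meant among the compounds shown, and "the series" means these compounds.

- compound 1 `C=CC(=O)Nc1cc2c(Nc3ccc(OCc4cccc(F)c4)c(Cl)c3)ncnc2cc1OCc1cn(CCCC(=O)NO)nn1`: 12000 nM
- compound 2 `CN(C)C/C=C/C(=O)Nc1cc2ncnc(Nc3ccc(F)c(Cl)c3)c2cc1O[C@@H]1CCOC1`: 740 nM

In a functional assay on NCI-H1975 cells (Homo sapiens) for antiproliferative activity, read by MTT assay, with a stated time of 72 h (on this read-out lower numbers stand for stronger inhibition and higher numbers for weaker inhibition), compound 1 has the higher number of the pair, at 12000 nM. Compound 2 lies lower at 740 nM, and this gap is beyond the usual scatter of repeated measurements.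

Compound 3 `C=CC(=O)Nc1cc2c(Nc3ccc(F)c(Cl)c3)ncnc2cc1OCc1cn(CCCC(=O)NO)nn1` has not yet been measured. It differs from compound 1 by having fluoro in place of (3-fluorobenzyl)oxy on an aromatic carbon. Among the measured compounds shown here, no measured pair shows what this swap does, so any forecast remains loose. Compound 1 sits at the top of the small range seen so far at 12000 nM, which leaves more room for a fall than a rise in this assay. The expected step, a 3.4-fold lower number from compound 1 to compound 3 (0.54 log units; beyond the scatter), is toward stronger inhibition. Compound 3 is estimated at 3500 nM, with an expected range of 800 nM to 12000 nM.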

Compound 3, half-maximal inhibitory concentration: 1820 nM
Beside the measured number, compound 3's estimate is 1.9-fold (0.28 log units) above it, within the range that was stated.
By their numbers in this assay, from the lowest: compound 2; then compound 3; then compound 1.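

Among the compounds shown here, replacing (3-fluorobenzyl)oxy with fluoro on this aromatic carbon gives a 6.6-fold lower number from compound 1 to compound 3 (0.82 log units; beyond the scatter) in this assay and is the first change at this position that can be read on its own. Compound 1 and compound 2 differ in more than one place, so their gap could not isolate it. In this pair, the large group with its six-membered aromatic ring is not needed for activity in these cells, and the data shown give no measured reason for the step.

With only fluoro and (3-fluorobenzyl)oxy to compare, the compounds shown leave open whether the number depends on the size of the group or on something else. A methoxy group, an amine or a plain benzyloxy group on this carbon would help tell these possibilities apart.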